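The source may report more compounds than this note shows. Statements on the series, on what has been measured and on what is new or still open speak of the compounds shown alone.

Measured compounds and their values in an assay on CHO cells for displacement of a labelled ligand from adenosine receptor A1 (Homo sapiens), read by scintillation counting, tested at 10 uM; a higher number here means more inhibition at the concentration tested (going by the name of the read-out), a lower number less inhibition:
compound 1 `Cc1c(-c2ccccc2)sc(N)c1C(=O)c1ccc(Cl)cc1` — 1%
compound 2 `Nc1sc(-c2ccccc2)c(-c2ccccc2)c1C(=O)c1ccc(Cl)cc1` — 1%
compound 3 `CC(C)(C)Cc1c(-c2c(F)cccc2F)sc(N)c1C(=O)c1ccc(Cl)cc1` — 1%

All three measured compounds sit at the floor of this assay. Going by the values given here, the only step between compounds that differ in one place, no change at the digits printed from compound 1 to compound 2 (within the scatter), lies within the scatter. Compound 3 stands level with compound 1 and compound 2.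

Compound 4 `CC(C)c1ccc(-c2sc(N)c(C(=O)c3ccc(Cl)cc3)c2CC(C)(C)C)cc1` is reached from compound 3 by 4-isopropylphenyl in place of 2,6-difluorophenyl on an aromatic carbon. Among the compounds with values here, no measured step touches this change directly; the one step on record, phenyl in place of methyl, left the number where it was. With nothing in the series rising off the floor, compound 4 is expected to stay there as well, with a number 2 percentage points higher from compound 3 to compound 4 (within the scatter) expected to be no step beyond the scatter. The estimate for compound 4 is 3%, in the range -8% to 15%.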

Compound 4, a percentage reported as inhibition, at one concentration (the size of the read-out at that concentration, not a potency): 1%
Estimate against measurement, compound 4: 2 percentage points above, within the range that was stated.
By their numbers in this assay, from the lowest: compounds 1, 2, 3 and 4 (each within the scatter of the next).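

In this assay, 4-isopropylphenyl in place of 2,6-difluorophenyl on the carbon next to the ring sulfur gives no change at the digits printed from compound 3 to compound 4 (within the scatter). Going by these compounds alone, this is the only single-place step on record at this position, since the earlier one, no change at the digits printed from compound 1 to compound 2 (within the scatter), lies at another ring carbon. With both compounds at the floor, it shows that this aryl exchange brings no gain, but a loss could not be seen.

Going by these compounds, whether an amine or a carboxylic acid at this carbon would lift the number off the floor remains open. No evidence on the cause of these flat values is available.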